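Removing the Trifluoroethyl Group from a Hydrazide

This account rests on a few compounds, and the source may have more. Where it says the series, first, only, none or still open, it means among the compounds named here.

Compound 1 `O=C(NNc1c(Br)cccc1Br)c1ccc(OCC(F)(F)F)cc1` is examined in a toxicity assay on MDCK cells (Canis lupus familiaris) for cytotoxicity, read by CCK-8 assay, with a stated time of 48 h; on this read-out higher numbers stand for lower toxicity in this test and lower numbers for higher toxicity in this test. In this assay compound 1 gives > 100000 nM, which is a limit of the assay rather than a number. Compound 2 `Cc1ccc(C(=O)NNc2c(Cl)cccc2Cl)cc1` also gives > 100000 nM in this assay, again a limit. Both measured compounds thus share one point, (the limit of > 100000 nM in this assay, at which 2 of the 2 values shown sit). Compound 3 `O=C(NNc1c(Br)cccc1Br)c1ccc(O)cc1` differs from compound 1 by hydrogen in place of 2,2,2-trifluoroethyl on an oxygen on an aromatic ring. Among the measured compounds shown here, no step between measured compounds is known, so the expectation for compound 3 rests on that shared limit alone. The change is expected to give a step that the limit leaves unreadable from compound 1 to compound 3 in this assay, nothing beyond the scatter. Compound 3 is estimated at 150000 nM, within 60000 nM and 400000 nM.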

Compound 3, half-maximal cytotoxic concentration: > 100000 nM
Compound 3: a limit, no number; the forecaster's own chance of this, stated with the estimate: 80%; the middle value lies beyond the limit too.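

No step can be read between compound 1 and compound 3, as both values are limits: the limit of > 100000 nM in this assay, at which 3 of the 3 values shown sit. The compounds shown leave open whether 2,2,2-trifluoroethoxy to hydroxy changes the half-maximal cytotoxic concentration at all.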